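Removal of the methylsulfonyl-bearing group from the shared core

The compounds below may be only part of what the source reports. "The series", "measured", "known", "first", "only" and "open" are said of these compounds alone.

Compound 3 `CC(C)(c1cc([C@@]23CCOC[C@@H]2C3)nc(-c2cccc(O)c2)n1)S(C)(=O)=O` stands at 4.8 in a physicochemical assay for lipophilicity (on this read-out higher numbers stand for higher lipophilicity and lower numbers for lower lipophilicity), level with compound 2 `CC(C)(c1cc([C@]23CCOC[C@H]2C3)nc(-c2cccc(O)c2)n1)S(C)(=O)=O` at 4.8; the two together are the highest of the three numbers, and compound 1 `CS(=O)(=O)Cc1cc(C2=CCOCC2)nc(-c2cccc(O)c2)n1` at 3.3 is the furthest away. Among the compounds with values here, the only measured step, no change at the digits printed from compound 2 to compound 3 (within the scatter), is consistent with the fact that compounds 2 and 3 differ only in the configuration as drawn and leaves the rest of the structure untouched, so it does not speak to what happens here. Compound 4 `Oc1cccc(-c2nccc([C@@]34CCOC[C@@H]3C4)n2)c1` differs from compound 3 by hydrogen in place of 1-methyl-1-(methylsulfonyl)ethyl on an aromatic carbon. Within the data shown here, no measured pair in this assay covers such a change, so the expectation for compound 4 rests on the structural change alone: the step of a number 0.60 log units higher from compound 3 to compound 4 (beyond the scatter) is expected to be a modest rise, beyond the scatter. Compound 4 is therefore estimated at 5.4, within 4.7 to 6.1.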

Compound 4, partition coefficient: 4
For compound 4 the middle estimate is 1.40 log units above the measured one; the measured number lies below the stated range.
By their numbers in this assay, from the lowest: compound 1; then compound 4; then compounds 2 and 3 (each within the scatter of the next).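

Replacing 1-methyl-1-(methylsulfonyl)ethyl by hydrogen on this aromatic carbon gives, in this assay, a number 0.80 log units lower from compound 3 to compound 4 (beyond the scatter). The read-out therefore responds to the substituent at this position, whereas the earlier step, a change of configuration only, gave no change at the digits printed from compound 2 to compound 3 (within the scatter). Nothing in the available evidence bears on the direction or size of this step.

As far as these compounds go, whether the step follows the whole 1-methyl-1-(methylsulfonyl)ethyl group or only its sulfonyl part remains open. Also open, from the compounds shown here alone, is how a methyl, an amine or a carboxylic acid on this carbon would read.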